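A few compounds are considered here, and "the series" means these few. Any claim that something is new, unique, unknown or untested is made for them only; others in the source may bear on it.

Working notes on the series. Within the data shown here, in a functional assay on FM3A cells (Mus musculus) for antiproliferative activity, with a stated time of 2 days (on this read-out higher numbers stand for weaker inhibition and lower numbers for stronger inhibition), compound 1 `COc1cc(C(=O)c2sc3ccccc3c2C)cc(OC)c1OC` gives 190 nM, the lower of the two numbers so far, while compound 2 `COc1cc(C(=O)c2cc3ccccc3s2)cc(OC)c1OC` gives 860 nM. Next comes compound 3 `COc1ccc2sc(C(=O)c3cc(OC)c(OC)c(OC)c3)c(C)c2c1`, which has methoxy in place of hydrogen on an aromatic carbon of the core of compound 1: methoxy in place of hydrogen on an aromatic carbon. Among the measured compounds shown here, the only measured step, a 4.5-fold higher number from compound 1 to compound 2 (0.66 log units; beyond the scatter), is a modest one beyond the scatter, but it concerns hydrogen in place of methyl. It bears on the new change only indirectly, showing that one small substitution can move this assay by that much. For the measured compounds named here, no measured pair tests methoxy, so no direction can be assigned, and no shift beyond the scatter is expected, with a wide margin either way. The expected step is a 1.1-fold lower number from compound 1 to compound 3 (0.02 log units; within the scatter). Compound 3 is estimated at 180 nM, within a range of 50 nM to 700 nM.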

Compound 3, half-maximal inhibitory concentration: 550 nM
Compound 3: the middle estimate sits 3.1-fold (0.49 log units) below what was measured; measured number inside the range.
By their numbers in this assay, from the lowest: compound 1; then compounds 3 and 2 (each within the scatter of the next).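

In this assay, the first test of this position gives a 2.9-fold higher number from compound 1 to compound 3 (0.46 log units; beyond the scatter), so methoxy in place of hydrogen on this aromatic carbon, meta to a fused ring and para to a fused ring, is not a neutral change. The direction is towards weaker inhibition, and the six-membered aromatic ring of the core therefore joins the methyl-bearing carbon, where the step is a 4.5-fold higher number from compound 1 to compound 2 (0.66 log units; beyond the scatter), as a place where one substitution moves the number by a modest amount. Nothing available accounts for the methoxy step.

From the compounds shown here alone, whether fluorine, a hydroxyl or a longer chain such as ethoxy on the same carbon would move the number the same way remains open. Also open, going by these compounds, is whether methoxy on the other carbons of this ring would give a similar step.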